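Switching the Nitrogen Substituent from Fluorophenyl to Sulfonylpyridinylmethyl

This account rests on a few compounds, and the source may have more. Where it says the series, first, only, none or still open, it means among the compounds named here.

Of the compounds shown here, three sharing one core have been measured in a physicochemical assay for lipophilicity, at pH 7.4; on this read-out lower numbers stand for lower lipophilicity and higher numbers for higher lipophilicity. Compound 1 `CCc1ccc(N(CC(C)C)S(=O)(=O)c2ccc3c(c2)C(OC2CCCCC2)CC(C2CCOCC2)O3)cc1` gives 6.28, compound 2 `CC(C)CN(c1ccc(F)cc1)S(=O)(=O)c1ccc2c(c1)C(O)CC(C1CCOCC1)O2` gives 3.39, and compound 3 `CCc1ccc(N(CC(C)C)S(=O)(=O)c2ccc3c(c2)C(N)CC(C2CCOCC2)O3)cc1` gives 3.08. Compound 2 thus stands second highest of the three: compound 3 lies nearest, a step below it that is beyond the scatter, while compound 1 lies furthest, well above it. Going by the values given here, the only single-point step so far is a number 3.20 log units lower from compound 1 to compound 3 (beyond the scatter), a large drop tied to the saturated ring carbon.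

Compound 4 `CCS(=O)(=O)c1ccc(CN(CC(C)C)S(=O)(=O)c2ccc3c(c2)C(O)CC(C2CCOCC2)O3)nc1` is the unmeasured compound. It differs from compound 2 at the sulfonamide nitrogen: (5-(ethylsulfonyl)pyridin-2-yl)methyl in place of 4-fluorophenyl on a sulfonamide nitrogen. Among the compounds with values here, no measured pair changes the group on that nitrogen, so the step from compound 1 to compound 3 bears on it only in showing that a single exchange on this core can shift this assay by a large amount. Given compound 2 at 3.39, the author expects compound 4 to come out lower, an estimated a number 1.69 log units lower from compound 2 to compound 4 (beyond the scatter), placing compound 4 at an estimated 1.7 with a likely range from 0.9 to 2.5. The measurement will tell.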

Compound 4, distribution coefficient: 1.42
For compound 4 the middle estimate is 0.28 log units above the measured one; low and high end bracket the measured number.
By their numbers in this assay, from the lowest: compound 4; then compound 3; then compound 2; then compound 1.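

The sulfonamide nitrogen is now a second place on the shared core where a single exchange moves this assay by a large amount: putting (5-(ethylsulfonyl)pyridin-2-yl)methyl in place of 4-fluorophenyl gives a number 1.97 log units lower from compound 2 to compound 4 (beyond the scatter). Going by these compounds alone, until now, the only step available came from the saturated ring carbon, so the size of any change at the nitrogen could not be read. The number falls here even though the entering group has 12 heavy atoms against 7 in the group that leaves, and it brings 3 hydrogen-bond acceptors where the leaving group has none, but no supporting measurement is available to explain the drop.

The compounds shown leave open which part of the entering group carries the step, the ethylsulfonyl group, the ring nitrogen or the methyl link, and a benzyl or 4-fluorobenzyl group on the sulfonamide nitrogen would help to separate these parts. From the compounds shown here alone, it also remains open whether the exchange gives a step of similar size when an amino group stands on the saturated ring carbon in place of the hydroxyl group.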